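Swapping an ethyl for a 3-fluoro-2-methoxyphenyl on a ring nitrogen

The source may report more compounds than this note shows. Statements on the series, on what has been measured and on what is new or still open speak of the compounds shown alone.

Two compounds that share a long chain ending in a benzene ring have been tested so far. In a functional assay on HOS cells (Homo sapiens) for inhibition, read by CCK-8 assay, with a stated time of 72 h, tested at 1 uM (a lower number here means less inhibition, a higher number more inhibition at the concentration tested (going by the name of the read-out)), compound 1 `CCN1C(=O)CSC1c1cccc(C(=O)NCCCCc2ccccc2)c1` gives 6%. Compound 2 `O=C(NCCCCc1ccccc1)c1cccc(C2OCC(=O)N2c2cccc(F)c2)c1` differs from compound 1 in several places. In this assay compound 2 gives 29%. Compound 1 thus has the lowest value of the two, and the gap to compound 2 is wider than the usual scatter of repeated measurements.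

Compound 3 `COc1c(F)cccc1N1C(=O)CSC1c1cccc(C(=O)NCCCCc2ccccc2)c1` has not yet been measured. It differs from compound 1 in one place: 3-fluoro-2-methoxyphenyl in place of ethyl on an amide-type nitrogen in a ring.

For the measured compounds named here, no single-point step between measured compounds is available, so the size of this change has to be guessed. Because compound 2 reaches 29% while compound 1 sits at 6%, a rise beyond the scatter seems plausible, though the two measured compounds differ in more than this one group. The expected step in this assay is a number 14 percentage points higher from compound 1 to compound 3 (beyond the scatter). For compound 3 the estimated inhibition in this assay is 20%, with a likely range from 4% to 40%.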

Compound 3, a percentage reported as inhibition, at one concentration (the size of the read-out at that concentration, not a potency): 9%
For compound 3 the middle estimate is 11 percentage points above the measured one; the range from low to high includes it.
By their numbers in this assay, from the lowest: compounds 1 and 3 (each within the scatter of the next); then compound 2.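

In this assay, putting 3-fluoro-2-methoxyphenyl in place of ethyl on the amide-type nitrogen in the ring gives a number 3 percentage points higher from compound 1 to compound 3 (within the scatter), so the two compounds cannot be told apart at the concentration tested. This position therefore takes a much larger group, one that brings a six-membered aromatic ring, without the read-out moving clear of the scatter, and this change alone does not produce a value that stands apart from compound 1. Nothing measured here explains this result, and no separate data on these compounds bear on it.

From the compounds shown here alone, whether another group on this nitrogen, such as a plain phenyl, a benzyl or a longer chain ending in an amine, would stand apart from compound 1 remains open. Compound 1 and compound 2 differ in several places, and these compounds do not show which of those places goes with the value of compound 2 at 29%.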